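The source may hold more compounds than are shown below. What is called first, only, known or untested is meant among the compounds shown, and "the series" means these compounds.

Compound 1, `CCOC(=O)c1oc2c(Br)c(OC)cc(OC)c2c1C`, in a functional assay on A549 cells (Homo sapiens) for cytotoxicity, read by MTT assay (on this read-out lower numbers stand for stronger inhibition and higher numbers for weaker inhibition), gives only a limit, > 87400 nM.
Compound 2, `CCCNC(=O)c1oc2c(C(N)=O)c(OC)cc(OC)c2c1C`, in this assay gives only a limit, > 93600 nM.

Compound 2 stands at a limit of this assay, not at a measured number, as the line the limit of > 93600 nM in this assay, at which 1 of the 2 values shown sits, records. For the measured compounds named here, the one other value shown, that of compound 1, is also a limit, as the line the limit of > 87400 nM in this assay, at which 1 of the 2 values shown sits, records, so neither compound shows measurable cytotoxicity here. Going by the values given here, compounds 1 and 2 differ in more than one place, and no step between them is known beyond what their two values show: both sit at limits.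

Compound 3, `COc1cc(OC)c2c(C)c(C(N)=O)oc2c1C(N)=O`, is not yet measured in this assay. It differs from compound 2 by hydrogen in place of propyl on an amide-type nitrogen. Among the compounds with values here, with no measured step to lean on, the account expects that the step from compound 2 to compound 3 stays within the scatter, with no shift in either direction beyond it, and that compound 3 most likely remains at a limit as well. The step that the limit leaves unreadable from compound 2 to compound 3 is therefore expected to be essentially none. Compound 3 is estimated at 95000 nM, with a range from 30000 nM to 300000 nM.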

Compound 3, half-maximal inhibitory concentration: 39400 nM
The estimate for compound 3 lay 2.4-fold (0.38 log units) above the measured number; low and high end bracket the measured number.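

Compound 3 is the first compound shown with a number rather than a limit in this assay, so a change on the amide-type nitrogen is enough to bring the read-out off the limit. Replacing propylcarbamoyl with carbamoyl gives an at least 2.3-fold lower number from compound 2 to compound 3 (0.37 log units; beyond the scatter), a step beyond the scatter that the two earlier compounds, both read only as limits, could not show. Compound 2 itself gives only a limit, so the step has a lower bound and no exact size: the limit of > 93600 nM in this assay, at which 1 of the 3 values shown sits.

The compounds shown leave open whether a methyl, an ethyl or a longer chain on this nitrogen would keep the number of compound 3, or whether any such group would return the read-out to the limit, and what a chain ending in an amine or a carboxylic acid would do there. Compound 1 differs from compound 3 in more than one place, so it cannot say how the other groups on the shared core contribute to this number, and the result rests on this single pair.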